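The source may report more compounds than this note shows. Statements on the series, on what has been measured and on what is new or still open speak of the compounds shown alone.

Measured compounds:
- compound 1 `Cc1ccccc1-c1cccc(NC(=O)C(Cl)Cl)c1`: 9860 nM
- compound 2 `O=C(Nc1cccc(-c2ccccc2)c1)C(Cl)Cl`: 8900 nM

In a functional assay on A549 cells (Homo sapiens) for cytotoxicity, read by MTT assay, with a stated time of 68 h (a lower number here means a stronger inhibitor, a higher number a weaker inhibitor), compound 2 gives 8900 nM. This sits within the scatter of the value for compound 1, so the two cannot be ranked.

The next compound to be read is compound 3 `O=C(Nc1cccc(-c2ccccc2Cl)c1)C(Cl)Cl`, which differs from compound 2 as follows: chloro in place of hydrogen on an aromatic carbon. Among the compounds with values here, one measured step bears on this change: a 1.1-fold lower number from compound 1 to compound 2 (0.04 log units; within the scatter). That step exchanges methyl and hydrogen on the same aromatic carbon that carries the chloro in compound 3. Within the data shown here, no chloro compound has been measured yet, so the support is indirect.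

Given the small size of a 1.1-fold lower number from compound 1 to compound 2 (0.04 log units; within the scatter), no step beyond the scatter is expected in this assay. The estimate means a 1.0-fold higher number from compound 2 to compound 3 (0.00 log units; within the scatter). For compound 3 the expected value is 9000 nM, with an estimated range from 4500 nM to 18000 nM.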

Compound 3, half-maximal inhibitory concentration: 22600 nM
For compound 3 the middle estimate is 2.5-fold (0.40 log units) below the measured one; measured number above the stated range.
By their numbers in this assay, from the lowest: compounds 2 and 1 (each within the scatter of the next); then compound 3.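

In this assay this position, on an aromatic carbon ortho to a large group, proves sensitive to what it carries: hydrogen and methyl could not be told apart there, but chloro gives a 2.5-fold higher number from compound 2 to compound 3 (0.40 log units; beyond the scatter) and, against methyl, a 2.3-fold higher number from compound 1 to compound 3 (0.36 log units; beyond the scatter). Both steps run the same way and are modest, so among the three groups seen at this carbon only chloro weakens the compound, and compound 1 and compound 2 stay level. Nothing available explains why chloro parts from methyl here.

On these data alone, it remains open whether the loss is particular to chloro or would also appear with a larger or different group at this carbon, such as methoxy, an amine or a carboxylic acid. As far as these compounds go, whether chloro elsewhere on the same ring gives a similar step is also open.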